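Trimming the methyl from the cyclohexyl of compound 1

This account rests on a few compounds, and the source may have more. Where it says the series, first, only, none or still open, it means among the compounds named here.

The measured compounds and their numbers:
Compound 1, `CC1CCC(C[C@H](CC(=O)N2CCOCC2)C(=O)N[C@]2(C#N)CCN(C3CCCCC3)C2)CC1`, gives 14 nM in an assay on isolated protein for inhibition of cathepsin S (Homo sapiens); on this read-out lower numbers stand for stronger inhibition and higher numbers for weaker inhibition.
Compound 2, `N#C[C@H](COCc1ccccc1)NC(=O)[C@@H](CC(=O)N1CCOCC1)CC1CCCCC1`, gives 37 nM in this assay.

Among these two, compound 1 stands with the lowest number, and the number of compound 2 lies higher by a gap that goes beyond the usual scatter of this assay. Among the measured compounds shown here, no step between the two measured compounds is counted here, since they differ in more than one place, so nothing direct is known about how a single change of this kind moves the read-out.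

Compound 3, `N#C[C@@]1(NC(=O)[C@@H](CC(=O)N2CCOCC2)CC2CCCCC2)CCN(C2CCCCC2)C1`, differs from compound 1 in one place only: hydrogen in place of methyl on a saturated ring carbon. For the measured compounds named here, no comparable step is available. The expectation rests on the general observation that such small trimmings tend to move this read-out only a little. For compound 3 the step of a 1.4-fold higher number from compound 1 to compound 3 (0.15 log units; within the scatter) is expected to be modest, with the number of compound 3 estimated to come out at 20 nM, most likely between 7 nM and 60 nM.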

Compound 3, half-maximal inhibitory concentration: 23 nM
The estimate for compound 3 lay 1.2-fold (0.06 log units) below the measured number; the measured number falls inside the stated range.
By their numbers in this assay, from the lowest: compounds 1, 3 and 2 (each within the scatter of the next, the first and the last beyond it).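

In this assay, among the compounds shown here, the first comparison in this set that changes a single place, taking the methyl off so that 4-methylcyclohexyl becomes cyclohexyl, gives a 1.6-fold higher number from compound 1 to compound 3 (0.22 log units; within the scatter) and so does not separate the two compounds. For this position, a saturated ring carbon three ring bonds from the ring atom that bears a large group, this means the methyl can be replaced by hydrogen with no change that this measurement can distinguish from ordinary repeat-to-repeat variation, and the small group is not required for the inhibition seen in compound 1. There is no supporting measurement that would explain why this position responds so little to the change.

On these data alone, only methyl and hydrogen have been compared on this ring carbon, so it remains open how the read-out would respond to a larger or differently built group there, such as tert-butyl, a hydroxyl or an amine. This single step also leaves open whether the same change would read the same way on a different core, such as that of compound 2, or on any other enzyme.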